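The source may hold more compounds than are shown below. What is called first, only, known or untested is meant among the compounds shown, and "the series" means these compounds.

Compound 1 `Cn1c(=O)c(=O)n(C2CCCC2)c2nc(N/N=C/c3ccc(F)c(Cl)c3)ncc21` — in a functional assay on PC-3 cells (Homo sapiens) for antiproliferative activity, read by MTT assay (a higher number here means a weaker inhibitor, a lower number a stronger inhibitor), compound 1 gives 8550 nM.
Compound 2 `Cc1cc(C)c(/C=N/Nc2ncc3c(n2)n(C2CCCC2)c(=O)c(=O)n3C)c(C)c1` — in this assay compound 2 gives 13900 nM.

Among the measured compounds shown here, of the two numbers measured so far, compound 2 holds the higher one, but its only neighbour is compound 1, and the step between them, a 1.6-fold higher number from compound 1 to compound 2 (0.21 log units; within the scatter), is within the scatter, so the two compounds cannot be separated on potency. Compound 3 `Cn1c(=O)c(=O)n(C2CCCC2)c2nc(N/N=C/c3ccc(O)c(Br)c3)ncc21` has not yet been measured. It differs from compound 2 in one place: 3-bromo-4-hydroxyphenyl in place of 2,4,6-trimethylphenyl on a carbon with a double bond to nitrogen. For the measured compounds named here, the one step that bears on this change is the swap of one aryl group for another at the same carbon, from compound 1 to compound 2, and that step stayed within the scatter. The new group brings a hydrogen-bond donor and acceptor that neither measured compound carries, and nothing measured here shows what such a group does in this assay. On the evidence at hand, a step no larger than the scatter is expected, leaning toward a somewhat lower number because compound 1, with a halogen-bearing aryl group, gave 8550 nM. Compound 3 is therefore estimated to give about 9000 nM in this assay, within a range of 3000 nM to 27000 nM, which is expected to amount to a 1.5-fold lower number from compound 2 to compound 3 (0.19 log units; within the scatter).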

Compound 3, half-maximal inhibitory concentration: 11600 nM
For compound 3 the middle estimate is 1.3-fold (0.11 log units) below the measured one; measured number inside the range.
By their numbers in this assay, from the lowest: compounds 1, 3 and 2 (each within the scatter of the next).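

In this assay, placing 3-bromo-4-hydroxyphenyl on the carbon with a double bond to nitrogen gives a 1.2-fold lower number from compound 2 to compound 3 (0.08 log units; within the scatter) and also a 1.4-fold higher number from compound 1 to compound 3 (0.13 log units; within the scatter), so three different aryl groups at this place now cannot be told apart on potency. Among the compounds shown here, the earlier pair showed this for only one swap, whereas this result extends it to a group with 1 hydrogen-bond donor and 1 hydrogen-bond acceptor, counts that are both 0 for the 2,4,6-trimethylphenyl group it replaces. In this assay, that difference in counts comes with no step beyond the usual scatter of repeated measurements, and no separate measurement is available to explain why these compounds fall so close together.

On these data alone, what remains open is whether any group at this place can produce a step beyond the scatter, for instance an amine or a carboxylic acid on the aromatic ring, or a saturated cyclohexyl ring in place of the aromatic one. The three compounds also share the rest of their structure, so they say nothing about how changes to the core would register in this assay.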